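Permeability of a sulfonamide series: from compound 2 to compound 4

The compounds below may be only part of what the source reports. "The series", "measured", "known", "first", "only" and "open" are said of these compounds alone.

Measured compounds:
Compound 1: `COc1cc(C)c(S(=O)(=O)N(C)CCOCC(=O)N2CCC(N3CCN(C(C)C)CC3)CC2)c(C)c1` — 0.9 10^-6 cm/s
Compound 2: `COc1cc(C)c(S(=O)(=O)N(C)CCOCC(=O)N2CCN(C3CCN(C4CC4)CC3)CC2)c(C)c1` — 11.8 10^-6 cm/s
Compound 3: `COc1cc(C)c(S(=O)(=O)N(C)CCOCC(=O)N(C)Cc2ccc(C3=NCCN3)cc2)c(C)c1` — 1.3 10^-6 cm/s

Three compounds sharing one core were tested in an ADME assay on Caco-2 cells (Homo sapiens) for permeability, tested at 50 uM; a lower number here means that the compound crosses the layer more slowly, a higher number that the compound crosses the layer faster. Compound 2 gives 11.8 10^-6 cm/s and stands highest of the three numbers. The nearest to it is compound 3, whose value of 1.3 10^-6 cm/s lies well outside the scatter below compound 2. The furthest is compound 1, with 0.9 10^-6 cm/s, also well beyond the scatter below compound 2. No pair among these three differs in only one place, so no single step can be read off between them.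

The next compound, compound 4, is `COc1cc(C)c(S(=O)(=O)N(C)CCOCC(=O)N2CCN(CC3CCN(C)CC3)CC2)c(C)c1`, not yet measured in this assay. It differs from compound 2 as follows: (1-methylpiperidin-4-yl)methyl in place of 1-cyclopropylpiperidin-4-yl on an amine nitrogen in a ring.

Within the data shown here, no measured step covers this change. Compound 2 is the only one of the three with a high number, and compound 4 keeps much of its arrangement on the amine nitrogen in the ring. A modest drop is expected for compound 4, somewhat beyond the scatter, as a 2.4-fold lower number from compound 2 to compound 4 (0.37 log units; beyond the scatter). The value estimated for compound 4 is 5 10^-6 cm/s, with a range from 1.5 10^-6 cm/s to 14 10^-6 cm/s.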

Compound 4, apparent permeability: 1.5 10^-6 cm/s
Beside the measured number, compound 4's estimate is 3.3-fold (0.52 log units) above it, within the range that was stated.
By their numbers in this assay, from the lowest: compounds 1, 3 and 4 (each within the scatter of the next); then compound 2.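

In this assay, among these compounds, putting (1-methylpiperidin-4-yl)methyl in place of 1-cyclopropylpiperidin-4-yl on an amine nitrogen in a ring gives a 7.9-fold lower number from compound 2 to compound 4 (0.90 log units; beyond the scatter), the first step in this set that differs in one place. It shows that this position is not indifferent to the group it carries, even though the two groups are alike in much of what is counted: each has one six-membered non-aromatic ring with 1 hetero atom, 1 hydrogen-bond acceptor, 0 hydrogen-bond donors and no net charge, and they hold 9 and 8 heavy atoms. What separates them is the three-membered carbon ring, present only in the leaving group, and the way the six-membered ring is attached, and nothing measured here accounts for the step.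

Among the compounds shown here, the single step changes these features together, so it remains open which of them goes with the lower number. As far as these compounds go, a 1-methylpiperidin-4-yl group or a (1-cyclopropylpiperidin-4-yl)methyl group at the same place would pull the two apart, and how far the high number of compound 2 depends on the cyclopropyl group itself also remains open.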